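This account rests on a few compounds, and the source may have more. Where it says the series, first, only, none or still open, it means among the compounds named here.

Measured so far in a functional assay on J774.A1 cells (Mus musculus) for inhibition, read by Griess assay, with stated times of 1 h and 24 h; a lower number here means a stronger inhibitor, a higher number a weaker inhibitor:
compound 1 `CCCCCOc1ccccc1C1CC(=O)c2ccccc2O1` gives 39300 nM
compound 2 `CC(C)=CCOc1ccccc1C1CC(=O)c2ccccc2O1` gives 34300 nM
compound 3 `COCOc1ccccc1C1CC(=O)c2ccccc2O1` gives 35200 nM

On these numbers, compound 2 is not separated from the other two compounds. Neither a 1.1-fold lower number from compound 1 to compound 2 (0.06 log units; within the scatter) nor a 1.0-fold higher number from compound 2 to compound 3 (0.01 log units; within the scatter) lies beyond the scatter, so the three values form a single group.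

The next compound to be measured is compound 4 `CCOc1ccccc1C1CC(=O)c2ccccc2O1`. Its difference from compound 2 is methyl in place of 2-methylprop-1-en-1-yl on a saturated chain carbon bound to an oxygen on an aromatic ring. Cut one bond further out, this reads 3-methylbut-2-en-1-yl to ethyl.

Among the measured compounds shown here, the closest precedent is a 1.0-fold higher number from compound 2 to compound 3 (0.01 log units; within the scatter), where the same 2-methylprop-1-en-1-yl leaves and methoxy enters. The other change at this place, a 1.1-fold lower number from compound 1 to compound 3 (0.05 log units; within the scatter), is also small and within the scatter. For the measured compounds named here, no compound in this small set goes against the flat picture, although three compounds are a thin base for it. No step beyond the scatter is therefore expected in this assay.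

The expected change is a 1.0-fold higher number from compound 2 to compound 4 (0.02 log units; within the scatter), and this estimate stays within the scatter. Compound 4 is expected at 36000 nM, with an estimated range from 22000 nM to 58000 nM.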

Compound 4, half-maximal inhibitory concentration: 38800 nM
Beside the measured number, compound 4's estimate is 1.1-fold (0.03 log units) below it, within the range that was stated.
By their numbers in this assay, from the lowest: compounds 2, 3, 4 and 1 (each within the scatter of the next).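

Working note on this place, on a saturated chain carbon bound to an oxygen on an aromatic ring: in this assay, replacing 2-methylprop-1-en-1-yl with methyl removes the double bond and reduces the group from 4 heavy atoms to 1, yet the result is only a 1.1-fold higher number from compound 2 to compound 4 (0.05 log units; within the scatter). The series now also includes a direct exchange of methyl for methoxy, a 1.1-fold higher number from compound 3 to compound 4 (0.04 log units; within the scatter), and a truncation of the chain, hydrogen in place of propyl two bonds along from that oxygen, a 1.0-fold lower number from compound 1 to compound 4 (0.01 log units; within the scatter), so neither the double bond, the methoxy group nor the extra chain length separates these four compounds. No supporting data bear on why the numbers stay flat here.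

The four compounds leave open whether an amine or a carboxylic acid at this place, or a chain much longer than butyl, would produce a step beyond the scatter. They also leave open whether changes elsewhere on the shared core would move the number, since all the variation shown lies in this one chain.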